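The compounds below may be only part of what the source reports. "The series", "measured", "known", "first", "only" and "open" are said of these compounds alone.

Measured so far:
compound 1 `CC(C)(C)Cc1c(-c2ccccn2)sc(N)c1C(=O)c1ccc(Cl)cc1` — 1%
compound 2 `CC(C)(C)Cc1c(-c2cc(F)ccc2F)sc(N)c1C(=O)c1ccc(Cl)cc1` — 3%

In an assay on CHO cells for displacement of a labelled ligand from adenosine receptor A1 (Homo sapiens), read by scintillation counting, tested at 10 uM (on this read-out higher numbers stand for more inhibition at the one concentration tested (going by the name of the read-out) and lower numbers for less inhibition), compound 1 gives 1% and compound 2 gives 3%. These two numbers lie within the scatter of each other, so neither compound can be set apart from the other. Going by the values given here, the one measured step, a number 2 percentage points higher from compound 1 to compound 2 (within the scatter), bears on the change to compound 3 `CC(C)(C)Cc1c(-c2ccc(Cl)c(Cl)c2)sc(N)c1C(=O)c1ccc(Cl)cc1`, which is 3,4-dichlorophenyl in place of 2,5-difluorophenyl on an aromatic carbon, since both changes replace the group on the same aromatic carbon. As that step stayed within the scatter, the step expected in this assay from compound 2 to compound 3 is no change at the digits printed from compound 2 to compound 3 (within the scatter), none beyond the scatter. Compound 3 is therefore estimated at 3%, with a range from -5% to 15%.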

Compound 3, a percentage reported as inhibition, at one concentration (the size of the read-out at that concentration, not a potency): 1%
For compound 3 the middle estimate is 2 percentage points above the measured one; the range from low to high includes it.
By their numbers in this assay, from the lowest: compounds 1, 3 and 2 (each within the scatter of the next).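

In this assay, putting 3,4-dichlorophenyl on the aromatic carbon next to the ring sulfur gives a number 2 percentage points lower from compound 2 to compound 3 (within the scatter) and no change at the digits printed from compound 1 to compound 3 (within the scatter). Pyridin-2-yl, 2,5-difluorophenyl and 3,4-dichlorophenyl therefore cannot be told apart at this position, and exchanging the two fluorines for two chlorines at other ring places leaves no readable difference. Nothing available explains this result. Going by these compounds, whether an amine, a carboxylic acid or a longer chain on this carbon would give a number beyond the scatter stays open. So does the effect of replacing the neopentyl group.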